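The source may hold more compounds than are shown below. What is called first, only, known or untested is meant among the compounds shown, and "the series" means these compounds.

Measured compounds:
compound 1, `COc1cccc(NC(=S)NCCNS(=O)(=O)c2ccc(-c3ccccc3Oc3ccc([N+](=O)[O-])cc3)s2)c1`: > 50000 nM
compound 2, `O=S(=O)(NCCNC(=S)Nc1cccc(Cl)c1)c1ccc(-c2ccccc2OCc2ccccc2)s1`: 8400 nM

Among the compounds with values here, in a functional assay on HeLa cells (Homo sapiens) for inhibition, read by CCK-8 assay, with a stated time of 48 h (on this read-out lower numbers stand for stronger inhibition and higher numbers for weaker inhibition), compound 2 gives 8400 nM, the only number among the values shown. For compound 1 the reading is a limit of the assay rather than a number, (the limit of > 50000 nM in this assay, at which 1 of the 2 values shown sits). So compound 2 stands alone as the single measured value, with nothing measured to compare it against, and no step between measured compounds is available.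

Compound 3, `O=S(=O)(NCCNC(=S)Nc1ccc(Cl)cc1)c1ccc(-c2ccccc2OCc2ccccc2)s1`, is not yet measured. It differs from compound 2 in one place: 4-chlorophenyl in place of 3-chlorophenyl on an amide-type nitrogen. Nothing among the shown values speaks to what such a move does in this assay, so the step is expected to stay within the usual scatter, in no particular direction: no change at the digits printed from compound 2 to compound 3 (within the scatter). Compound 3 is therefore estimated at 8400 nM, with a range from 3000 nM to 25000 nM.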

Compound 3, half-maximal inhibitory concentration: 7000 nM
For compound 3 the middle estimate is 1.2-fold (0.08 log units) above the measured one; low and high end bracket the measured number.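

In this assay, 4-chlorophenyl in place of 3-chlorophenyl on the amide-type nitrogen gives a 1.2-fold lower number from compound 2 to compound 3 (0.08 log units; within the scatter). Within the data shown here, the earlier compounds offered no step at all, so this is the first direct reading at this position: with the rest of the structure held the same, these two chlorophenyl groups cannot be told apart in this assay. The values shown offer no measured property that bears on this result.

It remains open what a plain phenyl, a cyclohexyl or a pyridyl group on this amide-type nitrogen would give on the same core, since the one step shown covers only two chlorophenyl groups. Equally open, on these data alone, is how compound 3 would read with a carbonyl in place of its thiocarbonyl.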